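Adding a Second Methoxy Group to the Benzyl Ring

A few compounds are considered here, and "the series" means these few. Any claim that something is new, unique, unknown or untested is made for them only; others in the source may bear on it.

Of the compounds shown here, two have been tested in a functional assay on MIA PaCa-2 cells (Homo sapiens) for antiproliferative activity, read by sulforhodamine B assay, with a stated time of 48 h; on this read-out lower numbers stand for stronger inhibition of growth and higher numbers for weaker inhibition of growth. Compound 1 `O=C(NCc1cn(Cc2ccc(C(F)(F)F)cc2)nn1)c1cn(-c2ccccc2)nc1-c1ccccc1` gives 17700 nM. Compound 2 `COc1ccc(Cn2cc(CNC(=O)c3cn(-c4ccccc4)nc3-c3ccccc3)nn2)cc1` gives 10200 nM. For the measured compounds named here, the only step between them, a 1.7-fold lower number from compound 1 to compound 2 (0.24 log units; within the scatter), is a methoxy in place of trifluoromethyl on an aromatic carbon. On these two numbers compound 2 has the lower value, but the gap to compound 1 is within the scatter, so no order between them can be claimed.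

Compound 3 `COc1ccc(Cn2cc(CNC(=O)c3cn(-c4ccccc4)nc3-c3ccccc3)nn2)cc1OC` differs from compound 2 by methoxy in place of hydrogen on an aromatic carbon. No measured step matches this change; the one step shown, from compound 1 to compound 2, altered a group at a different spot and stayed within the scatter. Compound 3 is therefore expected to give a value close to that of compound 2, with an estimated step of a 1.3-fold lower number from compound 2 to compound 3 (0.11 log units; within the scatter). The estimate for compound 3 in this assay is 8000 nM, within a range from 3000 nM to 25000 nM.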

Compound 3, concentration for 50% growth inhibition: 8200 nM
Compound 3: the middle estimate sits 1.0-fold (0.01 log units) below what was measured, within the range that was stated.
By their numbers in this assay, from the lowest: compounds 3, 2 and 1 (each within the scatter of the next, the first and the last beyond it).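

In this assay, placing a second methoxy on the ring, ortho to a methoxy group, turns 4-methoxybenzyl into 3,4-dimethoxybenzyl and gives a 1.2-fold lower number from compound 2 to compound 3 (0.09 log units; within the scatter), so no order can be claimed between these two compounds. For the compounds shown here, the larger swap of 4-(trifluoromethyl)phenyl for 3,4-dimethoxyphenyl gives a 2.2-fold lower number from compound 1 to compound 3 (0.33 log units; beyond the scatter), a modest step but the first here to pass beyond the scatter, which the single methoxy of compound 2 did not do. No measurement offered here explains these numbers.

Still open, as far as these compounds go, is what a different group on this same ring carbon would do, such as a hydroxy group, an amine or a carboxylic acid. From the compounds shown here alone, it is also open whether a longer chain in place of the methoxy would give a clearer step than these small ones.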